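Two triazole-linked analogues of a terpenoid scaffold in cytotoxicity

The compounds below may be only part of what the source reports. "The series", "measured", "known", "first", "only" and "open" are said of these compounds alone.

Measured so far:
Compound 1, `CC(C)=CCC/C(C)=C/CC/C(C)=C/CC[C@@H]1[C@@]2(C)CC/C(=N\OCc3cn(-c4cccc(Br)c4)nn3)C(C)(C)[C@@H]2CC[C@@]1(C)O`: 11700 nM
Compound 2, `CC(C)=CCC/C(C)=C/CC/C(C)=C/CC[C@@H]1[C@@]2(C)CC/C(=N\OCc3cn(-c4ccccc4C#N)nn3)C(C)(C)[C@@H]2CC[C@@]1(C)O`: 20000 nM
Compound 3, `CC(C)=CCC/C(C)=C/CC/C(C)=C/CC[C@@H]1[C@@]2(C)C/C(=C\c3ccc(OCc4cn(-c5cccc(Br)c5)nn4)cc3)C(=O)C(C)(C)[C@@H]2CC[C@@]1(C)O`: 33800 nM

All three were tested in a functional assay on A549 cells (Homo sapiens) for cytotoxicity, read by MTT assay, with a stated time of 48 h; a higher number here means a weaker inhibitor, a lower number a stronger inhibitor. Compound 1 and compound 2 share one core; compound 3 carries a different core, and the difference between the two cores is not broken down here. Compound 2 differs from compound 1 by a single change, (2-cyanophenyl in place of 3-bromophenyl on an aromatic nitrogen), which gave a 1.7-fold higher number from compound 1 to compound 2 (0.23 log units; within the scatter). The unmeasured compound 4, `CC(C)=CCC/C(C)=C/CC/C(C)=C/CC[C@@H]1[C@@]2(C)C/C(=C\c3ccc(OCc4cn(-c5ccccc5C#N)nn4)cc3)C(=O)C(C)(C)[C@@H]2CC[C@@]1(C)O`, carries the same change on the core of compound 3: 2-cyanophenyl in place of 3-bromophenyl on an aromatic nitrogen.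

Since the one earlier occurrence of this change, from compound 1 to compound 2, stayed within the scatter, compound 4 is expected to stay close to compound 3, with an estimated step of a 1.5-fold higher number from compound 3 to compound 4 (0.17 log units; within the scatter). Compound 4 is therefore estimated at 50000 nM, in a range from 20000 nM to 120000 nM.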

Compound 4, half-maximal inhibitory concentration: 61700 nM
The estimate for compound 4 lay 1.2-fold (0.09 log units) below the measured number; measured number inside the range.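

In this assay, putting 2-cyanophenyl in place of 3-bromophenyl gave a 1.8-fold higher number from compound 3 to compound 4 (0.26 log units; within the scatter), so on this second core the change again stayed within the scatter. The two occurrences agree closely: the same change on two cores in this assay, a 1.7-fold higher number (0.23 log units; within the scatter) from compound 1 to compound 2 and a 1.8-fold higher number (0.26 log units; within the scatter) from compound 3 to compound 4, 1.1-fold (0.03 log units) apart, within the scatter of two such steps. This shows that the change carried over between these two cores at much the same size, but it does not show that the change truly moves the number, and two cores cannot show how it would behave on a third.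

On these data alone, it remains open whether a different group on that aromatic nitrogen, such as a plain alkyl chain or a phenyl ring bearing a carboxylic acid or an amine, would move the number beyond the scatter. The compounds shown also leave open how an unsubstituted phenyl there would compare.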